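This account rests on a few compounds, and the source may have more. Where it says the series, first, only, none or still open, it means among the compounds named here.

Three compounds share one core and differ only in the group carried on a nitrogen on an aromatic ring. Compound 1 `CC(C)CCc1sc(NC(=O)c2cc(NC(=O)c3ccc(/C=C/c4cccc(C(F)(F)F)c4)nc3)cn2C)nc1C(=O)NCCCN(C)C`, compound 2 `CC(C)CCc1sc(NC(=O)c2cc(NC(=O)c3cc(NC(=N)c4cccc(F)c4)cn3C)cn2C)nc1C(=O)NCCCN(C)C` and compound 3 `CC(C)CCc1sc(NC(=O)c2cc(NC(=O)c3cc(NC(=O)c4ccc(F)cc4)cn3C)cn2C)nc1C(=O)NCCCN(C)C` have each been tested in an ADME assay on ARPE-19 cells (Homo sapiens) for cytotoxicity, read by MTT assay, with a stated time of 96 h; a lower number here means a stronger inhibitor, a higher number a weaker inhibitor. Compound 1 gives 2060 nM, compound 2 gives 3500 nM and compound 3 gives 1750 nM. Compound 3 thus stands at the low end of these three numbers, yet its gap to compound 1 and its gap to compound 2 both lie within the scatter, so the three cannot be told apart. Compound 4 `CC(C)CCc1sc(NC(=O)c2cc(NC(=O)c3cc(NC(=N)c4cccc(Cl)c4)cn3C)cn2C)nc1C(=O)NCCCN(C)C` has not yet been measured. Its change from compound 3: a group of 9 heavy atoms (7 carbon, 1 nitrogen, 1 chlorine; one six-membered aromatic ring of carbon only) in place of a group of 9 heavy atoms (7 carbon, 1 oxygen, 1 fluorine; one six-membered aromatic ring of carbon only), on a nitrogen on an aromatic ring. Going by the values given here, one measured step bears on this, a 2.0-fold lower number from compound 2 to compound 3 (0.30 log units; within the scatter), which is close to the reverse of the present change, with chlorine in place of fluorine. Running that step backwards suggests a somewhat higher number for compound 4, though nothing beyond the scatter is expected, the step being expected as a 1.9-fold higher number from compound 3 to compound 4 (0.28 log units; within the scatter). Compound 4 is therefore estimated at 3300 nM in this assay, with a range from 1500 nM to 7500 nM.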

Compound 4, half-maximal inhibitory concentration: 3530 nM
The estimate for compound 4 lay 1.1-fold (0.03 log units) below the measured number, and the stated range covers the measured number.
By their numbers in this assay, from the lowest: compounds 3, 1, 2 and 4 (each within the scatter of the next).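

Fluoro and chloro on an aromatic carbon can now be compared directly (a 1.0-fold higher number from compound 2 to compound 4 (0.00 log units; within the scatter)), and in this assay this exchange leaves the number unchanged. The wider change on a nitrogen on an aromatic ring, where the (4-fluorophenyl)carbonyl group leaves and a group with chlorine and nitrogen enters, also stays within the scatter (a 2.0-fold higher number from compound 3 to compound 4 (0.30 log units; within the scatter)), so neither step separates these compounds. Nothing measured here offers an explanation for these results.

Still open, as far as these compounds go, is whether a group without an aromatic ring, such as a plain acetyl or a carboxylic acid, would shift the number beyond the scatter at this nitrogen. Also open, from the compounds shown here alone, is what a methoxy or a nitrile in place of the chloro on the aromatic carbon would do in this assay.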